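The source may report more compounds than this note shows. Statements on the series, on what has been measured and on what is new or still open speak of the compounds shown alone.

Measured so far in a functional assay on HepG2 cells (Homo sapiens), read by MTT assay, with a stated time of 48 h; a higher number here means a weaker inhibitor, a lower number a stronger inhibitor:
compound 1 `CCN(CC)CCNC(=O)c1ccc(C(CC)(CC)c2ccc(OCC(=O)C(C)(C)C)c(C)c2)n1CC` gives 620 nM;
compound 2 `CCn1c(C(=O)NCCN(C)C)ccc1C(CC)(CC)c1ccc(OCC(=O)C(C)(C)C)c(C)c1` gives 2300 nM;
compound 3 `CCn1c(C(=O)NCCCN(C)C)ccc1C(CC)(CC)c1ccc(OCC(O)C(C)(C)C)c(C)c1` gives 360 nM.

Compound 2 and compound 1 differ in one place, (diethylamino in place of dimethylamino on a saturated chain carbon, two bonds along the chain from an amide-type nitrogen), and the step is a 3.7-fold lower number from compound 2 to compound 1 (0.57 log units; beyond the scatter). The values of compound 3 and compound 1 lie within the scatter of each other. The difference between the core of compound 3 and the core of compound 2 is not broken down here. Compound 4 `CCN(CC)CCCNC(=O)c1ccc(C(CC)(CC)c2ccc(OCC(O)C(C)(C)C)c(C)c2)n1CC` has not yet been measured; it differs from compound 3 by diethylamino in place of dimethylamino on a saturated chain carbon, three bonds along the chain from an amide-type nitrogen. Going by the values given here, this is the same kind of change as the one between compound 2 and compound 1, but not the same: the place is two bonds along the chain from an amide-type nitrogen in the one case and three bonds in the other. For compound 4 a step of about a 2.1-fold lower number from compound 3 to compound 4 (0.33 log units; beyond the scatter) in this assay is expected, resting on a 3.7-fold lower number from compound 2 to compound 1 (0.57 log units; beyond the scatter), with added uncertainty since the place differs. Compound 4 is therefore estimated at 170 nM, in a range from 60 nM to 500 nM.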

Compound 4, half-maximal inhibitory concentration: 1100 nM
Compound 4: middle estimate off by 6.5-fold (0.81 log units), on the low side; the whole stated range lies below it.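

In this assay, the change from dimethylamino to diethylamino gives a 3.1-fold higher number from compound 3 to compound 4 (0.49 log units; beyond the scatter), so the gain seen on the earlier core does not carry over to this one. On these two cores, the same change moves the number in opposite directions: the same change on two cores in this assay, a 3.7-fold lower number (0.57 log units; beyond the scatter) from compound 2 to compound 1 and a 3.1-fold higher number (0.49 log units; beyond the scatter) from compound 3 to compound 4, 11-fold (1.05 log units) apart, beyond the scatter of two such steps

This does not show which difference between the cores decides the direction, and the place of the change also differs, at two bonds along the chain from an amide-type nitrogen in one pair and three bonds in the other.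

The compounds shown leave open how this change behaves on a core that differs from that of compound 3 in one place only, such as one with a carbonyl in place of its hydroxyl. Also open, going by these compounds, is what a dipropylamino group or a longer chain would do.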